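The compounds below may be only part of what the source reports. "The series", "measured", "known", "first", "only" and "open" are said of these compounds alone.

Measured so far in a functional assay on ECa-109 cells for inhibition, with ECa-109 cell line (Homo sapiens) as the target, read by sulforhodamine B assay; on this read-out higher numbers stand for weaker inhibition and lower numbers for stronger inhibition:
compound 1 `Cc1ccc(NC2=CC(=O)c3nc4n(c3C2=O)[C@H]2OC[C@@H](O)[C@H]2OC4)cc1` gives 3480 nM;
compound 2 `O=C1C=C(NC2CCCCC2)C(=O)c2c1nc1n2[C@H]2OC[C@@H](O)[C@H]2OC1` gives > 16000 nM, which is a limit of the assay;
compound 3 `CCOc1ccc(NC2=CC(=O)c3nc4n(c3C2=O)[C@H]2OC[C@@H](O)[C@H]2OC4)cc1` gives 3210 nM.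

Compound 3 holds the lowest of the two numbers, though the gap to the other is slight: a 1.1-fold lower number from compound 1 to compound 3 (0.04 log units; within the scatter). Compound 2 sits at the limit of > 16000 nM in this assay, at which 1 of the 3 values shown sits.

Compound 4 `COc1ccccc1NC1=CC(=O)c2nc3n(c2C1=O)[C@H]1OC[C@@H](O)[C@H]1OC3` differs from compound 3 in one place: 2-methoxyphenyl in place of 4-ethoxyphenyl on an amine nitrogen. The measured step that most resembles it is a change of the substituent on the aromatic ring, a 1.1-fold lower number from compound 1 to compound 3 (0.04 log units; within the scatter), which stayed within the scatter. The steps of an at least 4.5-fold higher number from compound 1 to compound 2 (0.66 log units; beyond the scatter) and an at least 4.9-fold lower number from compound 2 to compound 3 (0.69 log units; beyond the scatter) concern exchange of the aromatic ring for cyclohexyl, and compound 4 keeps the ring. The expected step is therefore small, a 1.2-fold higher number from compound 3 to compound 4 (0.10 log units; within the scatter). Compound 4 is estimated at 4000 nM, between 1500 nM and 12000 nM.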

Compound 4, half-maximal inhibitory concentration: > 4000 nM
Compound 4 was reported as a limit; the forecaster's own chance of this, stated with the estimate: 15%; the middle value lies on the limit itself.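

Among these compounds, compound 4 is the first aromatic amine reported only as a limit: the limit of > 4000 nM in this assay, at which 1 of the 4 values shown sits. Its steps, an at least 1.2-fold higher number from compound 3 to compound 4 (0.09 log units; that floor lies within the scatter) and an at least 1.1-fold higher number from compound 1 to compound 4 (0.06 log units; that floor lies within the scatter), give only floors, so 2-methoxyphenyl on the amine nitrogen may match 4-ethoxyphenyl and 4-methylphenyl or fall well short of them. The step between compound 2 and compound 4 cannot be read, as both values are limits.

The compounds shown leave open how far this change raises the number. They also leave open how a phenyl ring carrying an amine or a carboxylic acid would read here.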